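A Nitrophenol Variant in an Arylsulfonyl Chalcone Series

This account rests on a few compounds, and the source may have more. Where it says the series, first, only, none or still open, it means among the compounds named here.

Compound 1 `CC(=O)Oc1ccc(/C=C(\C(=O)c2ccc(Cl)cc2)S(=O)(=O)c2ccc(C)cc2)cc1` is examined in a functional assay on DU-145 cells (Homo sapiens) for inhibition, read by trypan blue exclusion, with a stated time of 96 h (a lower number here means a stronger inhibitor of growth, a higher number a weaker inhibitor of growth), where compound 1 gives 25000 nM. Of the three measured compounds it has the second highest number: compound 2 `CN(C)c1ccc(/C=C(/SCc2ccc(Cl)c(Cl)c2)C(=O)c2ccc(Cl)cc2)cc1` gives 50000 nM, a gap within the scatter, while compound 3 `Cc1ccc(S(=O)(=O)/C(=C/c2ccc(Oc3ccccc3)cc2)C(=O)c2ccc(Cl)cc2)cc1` gives 1000 nM. Going by the values given here, the only one-place step, a 25-fold lower number from compound 1 to compound 3 (1.40 log units; beyond the scatter), shows that what sits on the oxygen on this aromatic ring can move the number a great deal. Compound 4 `Cc1ccc(S(=O)(=O)/C(=C/c2ccc(O)c([N+](=O)[O-])c2)C(=O)c2ccc(Cl)cc2)cc1` differs from compound 1 by 4-hydroxy-3-nitrophenyl in place of 4-acetoxyphenyl on a double-bonded chain carbon bound to a double-bonded chain carbon. Among the compounds with values here, no measured step covers this particular change; the step to compound 3 shows only that this part of the structure is sensitive. Compound 4 is therefore expected to show a 1.7-fold lower number from compound 1 to compound 4 (0.22 log units; within the scatter), with wide uncertainty, and its value in this assay is estimated at 15000 nM, between 3000 nM and 60000 nM.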

Compound 4, concentration for 50% growth inhibition: 25000 nM
The estimate for compound 4 lay 1.7-fold (0.22 log units) below the measured number, and the stated range covers the measured number.
By their numbers in this assay, from the lowest: compound 3; then compounds 1, 4 and 2 (each within the scatter of the next).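

In this assay, 4-hydroxy-3-nitrophenyl in place of 4-acetoxyphenyl gives no change at the digits printed from compound 1 to compound 4 (within the scatter), so a change of the whole substituted ring at this position need not move the number. The sensitivity suggested earlier therefore does not extend to every change here: of the two steps from compound 1, only a 25-fold lower number from compound 1 to compound 3 (1.40 log units; beyond the scatter) lies beyond the scatter. Nothing shown accounts for the difference between these two steps. On these data alone, since the hydroxy and nitro groups enter together in compound 4, their separate contributions remain open. Also open, as far as these compounds go, is how a benzyloxy group on this oxygen would compare with the phenyl of compound 3.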